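Swapping a Nitrophenyl for a Trifluoromethyl-Bearing Ring

A few compounds are considered here, and "the series" means these few. Any claim that something is new, unique, unknown or untested is made for them only; others in the source may bear on it.

Measured so far:
- Compound 1, `N#Cc1ccc(C(=O)Nc2cccc(NC(=O)COc3ccc4c(=O)ccoc4c3)c2)cc1`: 123 nM
- Compound 2, `O=C(COc1ccc2c(=O)ccoc2c1)Nc1cccc(NC(=O)c2cccc([N+](=O)[O-])c2)c1`: 528 nM

Both compounds were tested in an assay on isolated protein for inhibition of Rho-associated protein kinase 1 (Homo sapiens), read by scintillation counting, radiometric assay and 33P incorporation, with a stated time of 40 min, in the presence of a further agent that is not named here; a lower number here means a stronger inhibitor, a higher number a weaker inhibitor. For the measured compounds named here, compound 2 holds the highest of the two numbers, that is, it is the weaker of the two inhibitors; its only neighbour is compound 1, and the step between them, a 4.3-fold higher number from compound 1 to compound 2 (0.63 log units; beyond the scatter), is the sole piece of evidence on how the group attached to the carbonyl carbon matters.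

Compound 3, `Cc1cc(C(=O)Nc2cccc(NC(=O)COc3ccc4c(=O)ccoc4c3)c2)ccc1C(F)(F)F`, has not yet been measured. It differs from compound 2 in one place: a group of 11 heavy atoms (8 carbon, 3 fluorine; one six-membered aromatic ring of carbon only) in place of a group of 9 heavy atoms (6 carbon, 1 nitrogen, 2 oxygen; one six-membered aromatic ring of carbon only), on a carbonyl carbon.

Going by the values given here, the single measured step bears on this only loosely. It shows that changing the aryl group on that carbonyl carbon can move the number by a modest amount, but the entering group here carries no nitrogen or oxygen and is otherwise unlike either group already seen. A shift of about the same size as the known step is therefore plausible in either direction, with a slight lean toward a lower number, back toward the value of compound 1. Compound 3 is expected to give 280 nM, between 80 nM and 1000 nM, which would amount to an estimated step of a 1.9-fold lower number from compound 2 to compound 3 (0.28 log units; within the scatter).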

Compound 3, half-maximal inhibitory concentration: 460 nM
Compound 3: middle estimate off by 1.6-fold (0.22 log units), on the low side, and the stated range covers the measured number.
By their numbers in this assay, from the lowest: compound 1; then compounds 3 and 2 (each within the scatter of the next).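

In this assay, the 3-nitrophenyl group and the ring carrying trifluoromethyl and methyl cannot be told apart on this carbonyl carbon (a 1.1-fold lower number from compound 2 to compound 3 (0.06 log units; within the scatter)), although the entering group has 0 hydrogen-bond acceptors and the leaving group has 2. The nitrile-bearing ring of compound 1 now stands apart from two different rings rather than one (a 3.7-fold higher number from compound 1 to compound 3 (0.57 log units; beyond the scatter)), and among these three compounds it gives the strongest inhibitor, with both of its steps beyond the scatter. No measurement available here explains why these aryl groups rank as they do.

From the compounds shown here alone, it remains open whether an unsubstituted phenyl ring, a ring carrying an amine or a carboxylic acid, or a saturated ring such as cyclohexyl on this carbonyl carbon would come closer to compound 1 or to the other two compounds. Going by these compounds, it is also open whether the nitrile would keep compound 1 apart at another place on its ring, or with a methyl group added to that ring.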